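The source may report more compounds than this note shows. Statements on the series, on what has been measured and on what is new or still open speak of the compounds shown alone.

Compound 1, `COc1cc(NC(C)CCCNC(=O)Nc2ccc(Cl)c(C(F)(F)F)c2)c2ncccc2c1`: 23000 nM
Compound 2, `COc1cc(NC(C)CCCNC(=O)NNC(=O)Nc2ccc(Cl)c(C(F)(F)F)c2)c2ncccc2c1`: 15000 nM
Compound 3, `COc1cc(NC(C)CCCNC(=O)NNC(=O)NCCCCCO)c2ncccc2c1`: > 100000 nM

In a functional assay on SW-620 cells (Homo sapiens) for inhibition, read by MTT assay, with a stated time of 4 days (on this read-out lower numbers stand for stronger inhibition and higher numbers for weaker inhibition), compound 1 gives 23000 nM and compound 2 gives 15000 nM. Compound 3 stands at > 100000 nM in this assay, which is a limit of the assay and not a number. Compound 4, `COc1cc(NC(C)CCCNC(=O)NNC(=O)NCCCO)c2ncccc2c1`, is not yet measured; it differs from compound 3 by hydroxy in place of 2-hydroxyethyl on a saturated chain carbon, three bonds along the chain from an amide-type nitrogen. Two measured steps lead into compound 3: an at least 4.3-fold higher number from compound 1 to compound 3 (0.63 log units; beyond the scatter) and an at least 6.6-fold higher number from compound 2 to compound 3 (0.82 log units; beyond the scatter), both replacing the 4-chloro-3-(trifluoromethyl)phenyl with a hydroxyalkyl end. Nothing among these compounds shows a shorter hydroxyalkyl chain regaining activity, so the step of a number no higher from compound 3 to compound 4 (the limit leaves the size open) is expected to be none beyond the scatter. Compound 4 is therefore expected at 100000 nM, within 50000 nM to 300000 nM, most likely again reported as a limit.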

Compound 4, half-maximal inhibitory concentration: > 100000 nM
Compound 4 gave a limit, no number; the forecaster's own chance of this, stated with the estimate: 70%; the middle value lies on the limit itself.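

Compound 4 also stands at a limit, not a number, in this assay, so the step between compound 3 and compound 4 cannot be read: the limit of > 100000 nM in this assay, at which 2 of the 4 values shown sit.

Shortening 5-hydroxypentyl to 3-hydroxypropyl therefore brings back no measurable value. The shorter end still falls short of the 4-chloro-3-(trifluoromethyl)phenyl end, with an at least 6.6-fold higher number from compound 2 to compound 4 (0.82 log units; beyond the scatter) and an at least 4.3-fold higher number from compound 1 to compound 4 (0.63 log units; beyond the scatter).

Going by these compounds, whether the hydroxyalkyl ends differ from one another remains open. So does whether an amine or a carboxylic acid in place of the hydroxy on this chain would give a readable value.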